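The source may hold more compounds than are shown below. What is called first, only, known or untested is meant among the compounds shown, and "the series" means these compounds.

Compound 1, whose structure is `COc1ccc(/C=C/C(=O)c2c(OC)cc(O)c(CC=C(C)C)c2O)cc1OC`, compound 2, whose structure is `COc1cc(OC)c(OC)cc1/C=C/C(=O)c1c(OC)cc(O)c(CC=C(C)C)c1O`, and compound 3, whose structure is `COc1cc(/C=C/C(=O)c2c(O)cc(O)cc2OC)cc(OC)c1`, were all tested in a functional assay on HepG2 cells (Homo sapiens) for inhibition, read by MTT assay, with a stated time of 72 h; on this read-out lower numbers stand for stronger inhibition and higher numbers for weaker inhibition. In this assay compound 1 gives 13800 nM. In this assay compound 3 gives 17600 nM, which places it near compound 1 within the scatter of the method. Compound 2 does not yield a number in this assay but only a limit, > 50000 nM. The change from compound 1 to compound 2 is methoxy in place of hydrogen on an aromatic carbon and produces an at least 3.6-fold higher number from compound 1 to compound 2 (0.55 log units; beyond the scatter), a loss of activity whose full size cannot be stated because the limit of > 50000 nM in this assay, at which 1 of the 3 values shown sits, is the boundary at which the result sits.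

Compound 4, whose structure is `COc1cc(/C=C/C(=O)c2c(O)cc(O)cc2OC)cc(OC)c1OC`, has not yet been measured in this assay. It is built from compound 3 by methoxy in place of hydrogen on an aromatic carbon. Among the compounds with values here, this is the same kind of change as the one from compound 1 to compound 2, though not the same: the surroundings differ, since in the first case the new group stands ortho to a large group, meta to a methoxy group and para to a methoxy group, while in the second it stands ortho to two methoxy groups and para to a large group. The difference between the core of compound 1 and the core of compound 3 is not broken down here.

Resting on the single measured example, the step from compound 3 to compound 4 is expected to be a 2.6-fold higher number from compound 3 to compound 4 (0.41 log units; beyond the scatter), a weakening of activity in this assay. Compound 4 is therefore estimated to give 45000 nM in this assay, with the range 15000 nM to 150000 nM, and a real chance that only a limit is reported.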

Compound 4, half-maximal inhibitory concentration: 20400 nM
Compound 4: middle estimate off by 2.2-fold (0.34 log units), on the high side, and the stated range covers the measured number.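

In this assay, adding a methoxy group to compound 3, where it stands ortho to two methoxy groups and para to a large group, gives a 1.2-fold higher number from compound 3 to compound 4 (0.06 log units; within the scatter), so on this core the change has no effect that the assay can detect. The same replacement of hydrogen by methoxy therefore does not carry over with the same size from one core to the other, and a result on one core is a poor guide to the result on the other: the same change on two cores in this assay, an at least 3.6-fold higher number (0.55 log units; beyond the scatter) from compound 1 to compound 2 and a 1.2-fold higher number (0.06 log units; within the scatter) from compound 3 to compound 4, at least 3.1-fold (0.49 log units) apart, beyond the scatter of two such steps This does not show whether the core itself or the different surroundings of the new group set the two steps apart, and the true size of the gap stays open, since compound 2 gives only a limit: the limit of > 50000 nM in this assay, at which 1 of the 4 values shown sits.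

The compounds shown leave open how the same methoxy group would behave at other places on the ring of compound 3, and whether a third core would follow compound 2 or compound 4. They also leave open whether an amine or a carboxylic acid in the place of this methoxy group would shift the number in this assay on either core.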